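Expected effect of removing the methoxy from compound 3

The compounds below may be only part of what the source reports. "The series", "measured", "known", "first", "only" and "open" are said of these compounds alone.

Three analogues of one shared core have been run: compound 1 `Cc1ccc(C(=O)Nc2nn[nH]n2)nc1`, compound 2 `COc1cccnc1C(=O)Nc1nn[nH]n1` and compound 3 `COc1ccnc(C(=O)Nc2nn[nH]n2)c1`. In a functional assay on the whole organism for inhibition, with Rattus norvegicus as the target, at a dose of 10 mg/kg by the oral route (on this read-out higher numbers stand for a stronger effect at the one dose given and lower numbers for a weaker effect), compound 1 gives 42%, compound 2 gives 0% and compound 3 gives 88%. On these three numbers compound 3 stands highest; its nearest neighbour is compound 1, whose number lies lower by a gap beyond the usual scatter, and the furthest is compound 2, whose number lies lower still, again beyond the scatter. Compound 4 `O=C(Nc1nn[nH]n1)c1ccccn1` has not yet been measured in this assay. It differs from compound 3 in one place: hydrogen in place of methoxy on an aromatic carbon. For the measured compounds named here, no measured pair covers this change, so its effect in this assay is not known from the data. Compound 1 and compound 2 only show that the numbers in this set span the whole range. The working expectation is a downward step, larger than the scatter, as the top number belongs to compound 3 with the methoxy still present. Compound 4 is estimated at 55% in this assay, with a range from 20% to 85%. The expected step is a number 33 percentage points lower from compound 3 to compound 4 (beyond the scatter).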

Compound 4, a percentage reported as inhibition, in the whole organism at one dose (the size of the read-out at that dose, not a potency): 35%
Compound 4: the middle estimate sits 20 percentage points above what was measured; the range from low to high includes it.
By their numbers in this assay, from the lowest: compound 2; then compounds 4 and 1 (each within the scatter of the next); then compound 3.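

In this assay the methoxy opposite the ring nitrogen emerges as a large contributor to the number of compound 3, since hydrogen in its place brings a clear loss (a number 53 percentage points lower from compound 3 to compound 4 (beyond the scatter)). For the compounds shown here, the same exchange of methoxy for hydrogen runs the other way when the methoxy stands where compound 2 carries it (a number 35 percentage points higher from compound 2 to compound 4 (beyond the scatter)), so the direction of this change depends on where the methoxy sits on the ring, something the earlier compounds could not show with no single-place step among them, while the methyl of compound 1 and hydrogen are not told apart at the place compound 1 carries that methyl (a number 7 percentage points lower from compound 1 to compound 4 (within the scatter)). Nothing on hand gives a reason for either direction.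

Open, on these data alone, is whether methoxy is needed as such opposite the ring nitrogen, or whether a methyl, an ethoxy or a hydroxyl at that place would hold the number of compound 3. Also open, as far as these compounds go, is how an amine or a carboxylic acid would behave there, and whether a longer chain, such as propoxy, would carry the trend further or reverse it.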